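This account rests on a few compounds, and the source may have more. Where it says the series, first, only, none or still open, it means among the compounds named here.

Measured in a functional assay on HeLa cells (Homo sapiens) for inhibition, read by sulforhodamine B assay; a lower number here means a stronger inhibitor, a higher number a weaker inhibitor:

Compound 1 `Cc1ccc(NC2=CC(=O)c3nc4n(c3C2=O)[C@H]2OC[C@@H](O)[C@H]2OC4)cc1C`: 2690 nM
Compound 2 `CCCc1ccc(NC2=CC(=O)c3c(nc4n3[C@H]3OC[C@@H](O)[C@H]3OC4)C2=O)cc1`: 6030 nM
Compound 3 `CCOc1ccc(NC2=CC(=O)c3c(nc4n3[C@H]3OC[C@@H](O)[C@H]3OC4)C2=O)cc1`: 14400 nM

Compound 1 gives the lowest of the three numbers in this assay; compound 2 comes nearest to it and compound 3 lies furthest from it, both of those gaps beyond the scatter. The shared core is kept throughout; only the aryl group on the amine nitrogen changes.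

Compound 4 `COc1cccc(NC2=CC(=O)c3nc4n(c3C2=O)[C@H]2OC[C@@H](O)[C@H]2OC4)c1` is not yet measured. It differs from compound 1 as follows: 3-methoxyphenyl in place of 3,4-dimethylphenyl on an amine nitrogen

Among the compounds with values here, one measured step bears on this. It also trades an alkyl chain for an alkoxy group on an aromatic carbon: a 2.4-fold higher number from compound 2 to compound 3 (0.38 log units; beyond the scatter). Within the data shown here, the move to compound 4 removes both methyl groups of the aryl and brings in one methoxy, so a rise of the number at least as large as that step is the working expectation, with considerable uncertainty since no measured pair carries a methoxy or a mono-substituted aryl.

Compound 4 is therefore expected to give about 6500 nM in this assay, within 2700 nM to 16000 nM. The expected step is a 2.4-fold higher number from compound 1 to compound 4 (0.38 log units; beyond the scatter), a weaker inhibitor than compound 1.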

Compound 4, half-maximal inhibitory concentration: 4280 nM
Compound 4: the middle estimate sits 1.5-fold (0.18 log units) above what was measured; the measured number falls inside the stated range.
By their numbers in this assay, from the lowest: compounds 1, 4 and 2 (each within the scatter of the next, the first and the last beyond it); then compound 3.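

In this assay, the change from 3,4-dimethylphenyl to 3-methoxyphenyl on the amine nitrogen gives a 1.6-fold higher number from compound 1 to compound 4 (0.20 log units; within the scatter), so at this position both methyl groups can leave and one methoxy can enter without a step beyond the scatter. The earlier compounds shown here showed only an ethoxy-for-propyl exchange, a 2.4-fold higher number from compound 2 to compound 3 (0.38 log units; beyond the scatter), which lies beyond the scatter; the new step shows that an oxygen-linked group on the aryl does not always bring such a step, with compound 3 remaining the case that goes the other way, although the two steps differ in both the groups and the substitution pattern. No measurement here gives a reason for either step.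

Because both the removal of the methyl groups and the entry of the methoxy occur in one step, their separate contributions remain unresolved, and an unsubstituted phenyl would be the natural reference for separating them. From the compounds shown here alone, how far this position accepts other kinds of group, such as a carboxylic acid, a dimethylamino group or a longer alkoxy chain, also remains open.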